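Swapping the sulfonyl aryl group in a bromobenzyl sulfonamide

The source may hold more compounds than are shown below. What is called first, only, known or untested is meant among the compounds shown, and "the series" means these compounds.

Of the compounds shown here, two from this series have been tested in a functional assay on MIA PaCa-2 cells (Homo sapiens) for inhibition, read by MTT assay, with a stated time of 72 h; a higher number here means a weaker inhibitor of growth, a lower number a stronger inhibitor of growth. Compound 1 `O=S(=O)(NCCCCCCNCc1ccc(Br)cc1)c1ccc2c(c1)OCC2` gives 13000 nM in this assay, the highest number of the two; the nearest neighbour, compound 2 `O=S(=O)(NCCCNCc1ccc(-c2ccccc2)cc1)c1cc(C(F)(F)F)cc(C(F)(F)F)c1`, gives 2400 nM in this assay, a gap that lies beyond the scatter of repeated measurements. Going by the values given here, no pair of measured compounds differs in a single place, so no measured step is available as a guide.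

Compound 3 `COc1ccc(S(=O)(=O)NCCCCCCNCc2ccc(Br)cc2)cc1` keeps the core of compound 1 and changes only the group attached to the sulfonyl sulfur: a group of 8 heavy atoms (7 carbon, 1 oxygen; one six-membered aromatic ring of carbon only) in place of a group of 9 heavy atoms (8 carbon, 1 oxygen; one five-membered non-aromatic ring with 1 hetero atom, one six-membered aromatic ring of carbon only), on a sulfonyl sulfur. Nothing measured bears directly on this swap, since compound 2 differs from compound 1 in several places at once. The change is modest in size and keeps an aromatic ring bearing one oxygen at the same attachment point, so the step of a 1.2-fold higher number from compound 1 to compound 3 (0.06 log units; within the scatter) in this assay is expected to be small and probably within the scatter, in either direction. Compound 3 is therefore estimated at 15000 nM in this assay, with a plausible range from 6000 nM to 35000 nM.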

Compound 3, concentration for 50% growth inhibition: 13000 nM
Compound 3: middle estimate off by 1.2-fold (0.06 log units), on the high side, and the stated range covers the measured number.
By their numbers in this assay, from the lowest: compound 2; then compounds 1 and 3 (each within the scatter of the next).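

Going by these compounds alone, this is the first step that changes one place only, so it isolates the group on the sulfonyl sulfur, with the sulfonamide nitrogen and the rest of the core of compound 1 left as they are. In this assay, exchanging the fused group, with its five-membered non-aromatic ring, for an open 4-methoxyphenyl group gives no change at the digits printed from compound 1 to compound 3 (within the scatter) in growth inhibition, so for this pair the second ring makes no difference that the measurement can detect, and the single ring carrying one oxygen serves equally well at this position. Nothing available accounts for why these two groups read alike, and the finding rests on this one pair of compounds.

What the compounds shown leave open is whether this indifference holds for groups of a quite different kind on the sulfonyl sulfur, such as a carboxylic acid, an amine or a nitrile on the aromatic ring, or a simple phenyl ring with no oxygen at all. It is also unknown whether the same swap would read the same way on a shorter or longer chain, or with a group other than bromine on the benzyl ring.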